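The compounds below may be only part of what the source reports. "The series", "measured", "known", "first", "only" and "open" are said of these compounds alone.

Three compounds have been measured in a functional assay on the whole organism (strain Swiss albino) for inhibition, with Mus musculus as the target, in the writhing test, with a stated time of 30 min, at a dose of 100 mg/kg by the intraperitoneal route; a higher number here means more inhibition at the dose given (going by the name of the read-out), a lower number less inhibition:

Compound 1, `O=C(CSc1ccccc1C(=O)O)Nc1ccccc1`, gives 54.8%.
Compound 2, `Cc1ccc(NC(=O)CSc2ccccc2C(=O)O)cc1`, gives 76.3%.
Compound 3, `COc1ccc(NC(=O)CSc2ccccc2C(=O)O)cc1`, gives 27.7%.

All three share one core and differ only in a single group on an aromatic carbon. Compound 3 stands lowest of the three in this assay, and both gaps to the others lie beyond the scatter: the steps of a number 27.1 percentage points lower from compound 1 to compound 3 (beyond the scatter) and a number 48.6 percentage points lower from compound 2 to compound 3 (beyond the scatter) show how far it falls below compound 1 and compound 2.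

Compound 4, `O=C(CSc1ccccc1C(=O)O)Nc1ccc(C(=O)O)cc1`, differs from compound 3 in one place: carboxy in place of methoxy on an aromatic carbon.

For the measured compounds named here, no measured step involves a carboxy, so nothing here shows directly what this group does. Going by the values given here, the steps that bear on the change are the two in which the methoxy entered, a number 27.1 percentage points lower from compound 1 to compound 3 (beyond the scatter) and a number 48.6 percentage points lower from compound 2 to compound 3 (beyond the scatter), both lowering and both beyond the scatter. On these data alone, since the methoxy now leaves, the number may recover toward that of compound 1, while the effect of the entering carboxy remains unknown, so the estimate is uncertain in both directions. Compound 4 is therefore expected to give about 45%, within a range from 20% to 70%. The expected step is a number 17.3 percentage points higher from compound 3 to compound 4 (beyond the scatter), a rise that is not certain to exceed the scatter.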

Compound 4, a percentage reported as inhibition, in the whole organism at one dose (the size of the read-out at that dose, not a potency): 20.3%
Compound 4: middle estimate off by 24.7 percentage points, on the high side; measured number inside the range.
By their numbers in this assay, from the lowest: compounds 4 and 3 (each within the scatter of the next); then compound 1; then compound 2.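

In this assay, exchanging the methoxy for a carboxy on this aromatic carbon, para to a large group, gives a step too small to separate the two groups (a number 7.4 percentage points lower from compound 3 to compound 4 (within the scatter)). The carboxy group nevertheless stands well apart from both hydrogen (a number 34.5 percentage points lower from compound 1 to compound 4 (beyond the scatter)) and methyl (a number 56 percentage points lower from compound 2 to compound 4 (beyond the scatter)), so methoxy is no longer the only group shown here that goes with a lower number than hydrogen, while methyl in compound 2 goes the other way. No measurement on hand accounts for these differences.

On these data alone, four groups at one place cannot show how far the higher number seen with methyl extends, so it remains open whether a longer chain such as ethyl would follow compound 2, and whether an amine, a hydroxy group or a chlorine atom would instead fall with compound 3 and compound 4. Also open, as far as these compounds go, is whether methyl, methoxy and carboxy would keep this same order of effect on another carbon of the same ring.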